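The compounds below may be only part of what the source reports. "The series", "measured", "known", "first", "only" and "open" are said of these compounds alone.

In a functional assay on MIA PaCa-2 cells (Homo sapiens) for inhibition (a higher number here means a weaker inhibitor, a lower number a stronger inhibitor), compound 1 `O=C1O/C(=C\Cn2cc(C(F)(F)F)c(=O)[nH]c2=O)C(OCc2ccccc2)=C1OCc1ccccc1` gives 30000 nM and compound 2 `O=C1O/C(=C\Cn2cc(Br)c(=O)[nH]c2=O)C(OCc2ccccc2)=C1OCc1ccccc1` gives 80000 nM, the higher of the two numbers and so the weaker inhibitor of this pair. Compound 3 `O=C1O/C(=C\Cn2cc(F)c(=O)[nH]c2=O)C(OCc2ccccc2)=C1OCc1ccccc1` has not yet been measured. It keeps the shared core of compound 2 and changes one group: fluoro in place of bromo on an aromatic carbon, (fluoro in place of bromo on an aromatic carbon). Within the data shown here, only one measured step bears on this, a swap involving bromo on the same carbon: a 2.7-fold higher number from compound 1 to compound 2 (0.43 log units; beyond the scatter). That step is modest but beyond the scatter. A single comparison says little about direction, so a change of similar size towards a lower number is only a tentative expectation. The expected step is a 2.7-fold lower number from compound 2 to compound 3 (0.43 log units; beyond the scatter). Compound 3 is estimated at 30000 nM, with an expected range from 9000 nM to 100000 nM.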

Compound 3, half-maximal inhibitory concentration: 40000 nM
Compound 3: the middle estimate sits 1.3-fold (0.12 log units) below what was measured; the measured number falls inside the stated range.
By their numbers in this assay, from the lowest: compounds 1, 3 and 2 (each within the scatter of the next, the first and the last beyond it).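

In this assay, fluoro in place of bromo gives a 2.0-fold lower number from compound 2 to compound 3 (0.30 log units; within the scatter), and fluoro in place of trifluoromethyl gives a 1.3-fold higher number from compound 1 to compound 3 (0.12 log units; within the scatter), so compound 3 cannot be told apart from either of the other two compounds. The only difference beyond the scatter is still the one between compound 1 and compound 2, so swapping among these three groups on this aromatic carbon shifts the number only modestly. Nothing available explains why these groups give such similar numbers.

On these data alone, it remains open whether a different kind of group on this carbon, such as an amine, a carboxylic acid or a longer alkyl chain, would move the number much further. The compounds shown also leave open what plain hydrogen at this position would give, and whether changes elsewhere on the shared core matter more.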